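The compounds below may be only part of what the source reports. "The series", "measured", "known", "first", "only" and "open" are said of these compounds alone.

In a functional assay on PC-3 cells (Homo sapiens) for cytotoxicity, read by WST assay, with a stated time of 72 h (on this read-out lower numbers stand for stronger inhibition and higher numbers for weaker inhibition), compound 1 `CCOc1ccc(C2(c3ccc(O)cc3)C(=O)Nc3c2ccc(F)c3F)cc1` gives 24 nM, and compound 2 `O=C1Nc2c(ccc(F)c2F)C1(c1ccncc1)c1ccc(O)cc1` gives 110 nM. Compound 3 `O=C1Nc2c(ccc(F)c2F)C1(c1ccc(O)cc1)c1cccnc1` reads > 1000 nM, which is a limit of the assay and not a number. All three compounds differ on one saturated ring carbon, and exchanges there produced a 4.6-fold higher number from compound 1 to compound 2 (0.66 log units; beyond the scatter), an at least 41-fold higher number from compound 1 to compound 3 (1.61 log units; beyond the scatter) and an at least 9.0-fold higher number from compound 2 to compound 3 (0.95 log units; beyond the scatter). The read-out in this assay has therefore responded strongly to the group at this carbon.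

Compound 4 `CCCCCC1(c2ccc(O)cc2)C(=O)Nc2c1ccc(F)c2F` changes the same carbon, with pentyl in place of pyridin-3-yl on a saturated ring carbon. Among the measured compounds shown here, no measured step replaces a ring group with an open chain, so the direct evidence is thin. Pentyl has no ring nitrogen, and the two compounds with a pyridinyl group both gave higher numbers than compound 1 at 24 nM. On that basis, and given an at least 41-fold higher number from compound 1 to compound 3 (1.61 log units; beyond the scatter), a lower number than the limit of compound 3 is expected, though probably without a full return to the level of compound 1. The expected change is an at least 6.6-fold lower number from compound 3 to compound 4 (0.82 log units; beyond the scatter). For compound 4 the estimated value is 150 nM, with an expected range from 30 nM to 800 nM.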

Compound 4, half-maximal inhibitory concentration: 1.1 nM
Compound 4: middle estimate off by 140-fold (2.13 log units), on the high side, and the stated range ends above it.
By their numbers in this assay, from the lowest: compound 4; then compound 1; then compound 2. At a limit, above all of these: compound 3.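

In this assay, the pentyl chain at this saturated ring carbon gives a 22-fold lower number from compound 1 to compound 4 (1.34 log units; beyond the scatter), which shows that an aromatic ring is not needed there and that the lack of a ring nitrogen does not account for the whole result, since the 4-ethoxyphenyl group also has no ring nitrogen and still gives the higher number. Among the compounds shown here, the distance from the pyridinyl groups is wider still, with a 100-fold lower number from compound 2 to compound 4 (2.00 log units; beyond the scatter) and an at least 900-fold lower number from compound 3 to compound 4 (2.95 log units; beyond the scatter), so the values at this one carbon spread much further than the earlier compounds showed, and the open chain now holds the lowest number of the four. The last of these steps is only a bound, as compound 3 stands at a limit of the assay and not at a number: the limit of > 1000 nM in this assay, at which 1 of the 4 values shown sits.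

The compounds shown leave open whether pentyl is a particular optimum or one point in a trend, which a shorter propyl chain, a longer heptyl chain or a branched chain could test. They also leave open whether a saturated cyclohexyl ring would read like the open chain, and whether an amine at the end of the chain would keep the low number.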